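Removing the two hydroxyl groups from compound 1

The source may hold more compounds than are shown below. What is called first, only, known or untested is meant among the compounds shown, and "the series" means these compounds.

compound 1 `O=C(CCc1nc2ccccc2c(=O)[nH]1)N/N=C/c1ccc(O)c(O)c1` reads 40000000 nM
compound 2 `COc1cc(/C=N/NC(=O)CCCc2nc3ccccc3c(=O)[nH]2)ccc1O` reads 115000000 nM

In a physicochemical assay, read by spectrophotometry, with a stated time of 6 min (a lower number here means a stronger inhibitor, a higher number a weaker inhibitor), compound 1 gives 40000000 nM as the lower of the two numbers, and compound 2 gives 115000000 nM as a higher number, a gap beyond the usual scatter. Going by the values given here, compound 1 is therefore the stronger inhibitor of this small pair, although only two measurements are available.

Compound 3 `O=C(CCc1nc2ccccc2c(=O)[nH]1)N/N=C/c1ccccc1` has not yet been measured. It keeps the core of compound 1 but has phenyl in place of 3,4-dihydroxyphenyl on a carbon with a double bond to nitrogen, as counted in phenyl in place of 3,4-dihydroxyphenyl on a carbon with a double bond to nitrogen for the two structures.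

Among the compounds with values here, no measured pair shows this change on its own, so its size can only be judged loosely. With the 3,4-dihydroxyphenyl gone, a clear loss of strength in this assay is expected, meaning a higher number well beyond the scatter. The expected change is a 10-fold higher number from compound 1 to compound 3 (1.00 log units; beyond the scatter) in the direction of a weaker inhibitor. Compound 3 is estimated at 400000000 nM with an expected range of 100000000 nM to 2000000000 nM as the likely span.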

Compound 3, half-maximal inhibitory concentration: 265000000 nM
Beside the measured number, compound 3's estimate is 1.5-fold (0.18 log units) above it, and the stated range covers the measured number.
By their numbers in this assay, from the lowest: compound 1; then compound 2; then compound 3.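

In this assay, with the core of compound 1 held fixed, putting phenyl in place of 3,4-dihydroxyphenyl on a carbon with a double bond to nitrogen gives a 6.6-fold higher number from compound 1 to compound 3 (0.82 log units; beyond the scatter) and so a weaker inhibitor. Going by these compounds alone, this is the first reading of a single change at this position: compound 1 and compound 2 differ in more than one place, so that pair could not isolate it. The step lies beyond the usual scatter, which shows that the group at this position affects the reading, but nothing at hand explains why the number rises.

The compounds shown leave open whether a phenyl carrying a single hydroxyl group would keep part of the strength of compound 1, and whether an amine or a carboxylic acid on the ring could take the place of the hydroxyl groups. Within the data shown here, with only this one pair differing in one place, they also leave open whether the same change would give a step of similar size on a different chain.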